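A few compounds are considered here, and "the series" means these few. Any claim that something is new, unique, unknown or untested is made for them only; others in the source may bear on it.

Measured in a physicochemical assay for solubility; a higher number here means a more soluble compound, a lower number a less soluble compound:
- compound 1 `CNC(=O)c1cc(C(=O)NC2CC2)cn(Cc2ccc(OC)cc2)c1=O`: >= 143 ug/mL, a limit
- compound 2 `CCNC(=O)c1cc(C(=O)NC)c(=O)n(Cc2ccccc2)c1`: >= 144 ug/mL, a limit
- compound 3 `CNC(=O)c1cccn(Cc2ccccc2)c1=O`: 78 ug/mL

Compound 1 stands at a limit of the assay, >= 143 ug/mL, and not at a number. Its true position is therefore open on one side.

Compound 4 `CNC(=O)c1cc(C(=O)NC2CC2)cn(CC2CCCCC2)c1=O` carries cyclohexyl in place of 4-methoxyphenyl on a saturated chain carbon bound to an aromatic nitrogen. The counted difference is cyclohexyl in place of 4-methoxyphenyl on a saturated chain carbon bound to an aromatic nitrogen.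

The series offers a single measured step, an at least 1.8-fold lower number from compound 2 to compound 3 (0.26 log units; that floor lies within the scatter). That step replaces ethylcarbamoyl with hydrogen on an aromatic carbon, so it does not touch the place changed here and bears on this change only as a guide to how far values move within the series. Going by the values given here, no measured step covers a change on the saturated chain carbon.

Among the compounds with values here, compound 3 gives 78 ug/mL, which is the only true number available and anchors the lower part of the expected range. In this assay the expected change for an at least 1.4-fold lower number from compound 1 to compound 4 (0.15 log units; that floor lies within the scatter) is a modest lower number, with no confident expectation of a step beyond the scatter. For compound 4 the estimated value is 100 ug/mL, with an expected range from 40 ug/mL to 180 ug/mL.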

Compound 4, solubility: >= 148 ug/mL
Compound 4: a limit, no number (the forecaster's own chance of this, stated with the estimate: 35%); middle value at least 1.4-fold (0.17 log units) away from the limit.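

In this assay compound 4 stands at a limit, >= 148 ug/mL. Going by these compounds alone, compound 1 also stands at a limit, >= 143 ug/mL, so no step between compound 1 and compound 4 can be read. The compounds shown leave open whether cyclohexyl in place of 4-methoxyphenyl on a saturated chain carbon bound to an aromatic nitrogen changes the true value at all, and in which direction.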